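Notes on the step from compound 3 to compound 4

This account rests on a few compounds, and the source may have more. Where it says the series, first, only, none or still open, it means among the compounds named here.

Among the compounds with values here, compound 3 `CSCC[C@H](NC(=O)CN(c1nc(Cl)nc2[nH]cnc12)C1CC1)C(=O)O` gives 20.4% in a functional assay on the whole organism (Tail, strain ICR) with Mus musculus as the target, in the tail flick test, with a stated time of 30 min, at a dose of 25 umol/kg by the oral route (a lower number here means a weaker effect, a higher number a stronger effect of the compound at the dose given), the lowest of the three numbers so far. Compound 2 `NC(=O)C[C@H](NC(=O)CN(c1nc(Cl)nc2[nH]cnc12)C1CC1)C(=O)O` gives 29.7%, and the gap a number 9.3 percentage points lower from compound 2 to compound 3 (within the scatter) stays within the scatter. Compound 1 `N=C(N)NCCC[C@H](NC(=O)CN(c1nc(Cl)nc2[nH]cnc12)C1CC1)C(=O)O` gives 45.4%; the steps of a number 15.7 percentage points lower from compound 1 to compound 2 (beyond the scatter) and a number 25 percentage points lower from compound 1 to compound 3 (beyond the scatter) are both beyond the scatter. Compound 4 `NC(=O)CC[C@H](NC(=O)CN(c1nc(Cl)nc2[nH]cnc12)C1CC1)C(=O)O` differs from compound 3 by carbamoyl in place of methylsulfanyl on a saturated chain carbon, three bonds along the chain from an amide-type nitrogen and a carbonyl carbon. The closest comparison is the one within the scatter between compound 2 and compound 3, and nothing measured points to a large move in either direction. For compound 4 only a small rise is therefore expected, the step of a number 7.6 percentage points higher from compound 3 to compound 4 (within the scatter) being the estimate. For compound 4 a value of 28% is expected, between 15% and 42%.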

Compound 4, a percentage reported as activity, at one dose (the size of the read-out at that dose, not a potency): 33.1%
Compound 4: the middle estimate sits 5.1 percentage points below what was measured, and the stated range covers the measured number.
By their numbers in this assay, from the lowest: compounds 3, 2 and 4 (each within the scatter of the next, the first and the last beyond it); then compound 1.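

In this assay, carbamoyl in place of methylsulfanyl at this position gives a number 12.7 percentage points higher from compound 3 to compound 4 (beyond the scatter), whereas carbamoylmethyl in place of carbamoyl gives a number 3.4 percentage points higher from compound 2 to compound 4 (within the scatter), so the one-carbon extension of the amide side chain shows no resolved effect. Neither amide side chain matches the side chain of compound 1, with a number 12.3 percentage points lower from compound 1 to compound 4 (beyond the scatter) still standing. Nothing available explains these steps. Open, as far as these compounds go, is whether an amine or a carboxylic acid in place of carbamoyl on this chain closes that gap. Also open, from the compounds shown here alone, is whether a longer chain carrying carbamoyl moves the number.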